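The source may report more compounds than this note shows. Statements on the series, on what has been measured and on what is new or still open speak of the compounds shown alone.

Compound 2 `O=c1cc(Cn2cc(CCCO)nn2)c2ccc(O)cc2o1` and compound 1 `CC(O)c1cn(Cc2cc(=O)oc3cc(O)ccc23)nn1` share one core and differ in a single place, and both were measured in a functional assay on HepG2 cells (Homo sapiens) for inhibition, read by MTT assay, with a stated time of 72 h; on this read-out higher numbers stand for weaker inhibition and lower numbers for stronger inhibition. Compound 1 reaches only the limit of this assay, > 100000 nM. Compound 2 likewise reaches only the limit of this assay, > 100000 nM. Going by the values given here, the one measured step, a step that the two limits leave unreadable from compound 1 to compound 2, therefore cannot be read, and compound 2 stands nowhere more precise than at that limit (the limit of > 100000 nM in this assay, at which 2 of the 2 values shown sit).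

Compound 3 `CCCCCCCCc1cn(Cc2cc(=O)oc3cc(O)ccc23)nn1` is the next compound to be measured. It differs from compound 2 by pentyl in place of hydroxy on a saturated chain carbon, three bonds along the chain from an aromatic carbon; cut one bond further out, the same change reads as 3-hydroxypropyl to octyl. No measured step bears on this change, since the only step shown, from a 1-hydroxyethyl to a 3-hydroxypropyl group, is hidden by two limits. With no readable step to draw on, the expectation for compound 3 in this assay rests on the limit shared by compound 1 and compound 2 alone, and the step from compound 2 is expected to be an at least 1.2-fold lower number from compound 2 to compound 3 (0.09 log units; that floor lies within the scatter). Compound 3 is accordingly estimated at 80000 nM, within a range from 15000 nM to 400000 nM, with a real chance that this assay again reports only a limit.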

Compound 3, half-maximal inhibitory concentration: 34200 nM
The estimate for compound 3 lay 2.3-fold (0.37 log units) above the measured number; the measured number falls inside the stated range.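

In this assay, compound 3 gives the first number in this set that is not a limit, and the other two compounds stay at the limit: the limit of > 100000 nM in this assay, at which 2 of the 3 values shown sit. The change of 3-hydroxypropyl to octyl, read at its place as pentyl in place of hydroxy on a saturated chain carbon, three bonds along the chain from an aromatic carbon, gives an at least 2.9-fold lower number from compound 2 to compound 3 (0.46 log units; beyond the scatter), so this position is shown for the first time to respond to a change beyond the scatter. Octyl in place of 1-hydroxyethyl on an aromatic carbon gives an at least 2.9-fold lower number from compound 1 to compound 3 (0.46 log units; beyond the scatter), and both steps are floors, with their full size hidden by the limits at which they start.

The step to compound 3 lengthens the chain and removes the hydroxy at once, so the compounds shown do not separate the two changes, and an octyl chain carrying a hydroxy or a plain propyl chain would bear on that question. Going by these compounds, whether the trend continues with a longer chain such as dodecyl, or whether an amine or a carboxylic acid in place of the hydroxy would give a readable number, also stays open.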